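From 5-hydroxypentyl to 2-hydroxyethyl on compound 1

The source may report more compounds than this note shows. Statements on the series, on what has been measured and on what is new or still open speak of the compounds shown alone.

Compound 1 `COc1cc(NC(C)CCCNC(=O)NNC(=O)NCCCCCO)c2ncccc2c1`: >= 250000 nM
Compound 2 `CCOC(=O)NC(c1ccccc1)c1ccc(Cl)cc1`: > 250000 nM

Both compounds were tested in a functional assay on HeLa cells (Homo sapiens) for inhibition, read by MTT assay, with a stated time of 4 days; on this read-out higher numbers stand for weaker inhibition and lower numbers for stronger inhibition. In this assay compound 1 stands at >= 250000 nM, which is a limit of the assay and not a number. Compound 2 gives > 250000 nM, which is also a limit. Neither compound has a numerical value, so the two cannot be ranked. Among the compounds with values here, no measured pair differing in one place is available to size the coming change.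

Compound 3 `COc1cc(NC(C)CCCNC(=O)NNC(=O)NCCO)c2ncccc2c1` keeps the core of compound 1 and differs from it in one place. The change is hydroxy in place of 3-hydroxypropyl on a saturated chain carbon, two bonds along the chain from an amide-type nitrogen. It places hydroxy in place of 3-hydroxypropyl on a saturated chain carbon, two bonds along the chain from an amide-type nitrogen. Cut one bond further out, it reads 5-hydroxypentyl to 2-hydroxyethyl.

In this assay no step beyond the scatter is expected in either direction, because compound 1 gives >= 250000 nM. The estimated a number no higher from compound 1 to compound 3 (the limit leaves the size open) therefore stays within the scatter. Compound 3 is estimated at 250000 nM, with an expected range of 120000 nM to 500000 nM.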

Compound 3, half-maximal inhibitory concentration: 196000 nM
For compound 3 the middle estimate is 1.3-fold (0.11 log units) above the measured one, within the range that was stated.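

In this assay compound 1 gives >= 250000 nM, which is a limit of the assay and not a number. Compound 3, at 196000 nM, carries a true number, so the change from 5-hydroxypentyl to 2-hydroxyethyl can now be given a size, as an at least 1.2-fold lower number from compound 1 to compound 3 (0.10 log units; that floor lies within the scatter). The step has only a floor because its starting point is a limit, so the change is not shown to move the read-out beyond the scatter, and its true size remains unknown: the limit of >= 250000 nM in this assay, at which 1 of the 3 values shown sits.

The compounds shown leave open how the read-out follows the length of this chain, and whether the hydroxy group contributes at all, since both compound 1 and compound 3 carry one. They also give no answer for an amine or a carboxylic acid in place of the 2-hydroxyethyl group, or for a plain alkyl chain there, any of which would show whether this position can bring the number in this assay clearly below that of compound 3.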